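A few compounds are considered here, and "the series" means these few. Any claim that something is new, unique, unknown or untested is made for them only; others in the source may bear on it.

Of the compounds shown here, two sharing one core have been measured so far. Compound 1 `CCC1=C(O)c2c(oc(-c3ccc(CC)cc3)cc2=O)C(CC)(CC)C1=O` gives 21.9 uM in a functional assay on KB cells (Homo sapiens) for antiproliferative activity, read by sulforhodamine B assay, with a stated time of 3 days; a higher number here means that more compound is needed for the effect, a lower number that less compound is needed. Compound 2 `CCC1=C(O)c2c(oc(-c3ccc(CC(C)C)cc3)cc2=O)C(CC)(CC)C1=O` gives 29.3 uM in this assay. Going by the values given here, the single step between them, a 1.3-fold higher number from compound 1 to compound 2 (0.13 log units; within the scatter), is within the scatter, so the two numbers cannot be told apart. Compound 2 holds the higher of the two numbers, but with only compound 1 beside it, and that within the scatter, it stands nowhere in particular.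

Compound 3 `CCC1=C(O)c2c(oc(-c3ccc(OC(F)(F)F)cc3)cc2=O)C(CC)(CC)C1=O` is not yet measured. Compared with compound 2, it carries trifluoromethoxy in place of isobutyl on an aromatic carbon. Among the compounds with values here, the only measured step that bears on this is a 1.3-fold higher number from compound 1 to compound 2 (0.13 log units; within the scatter), which also altered the group on that aromatic ring and produced no change beyond the scatter. That step, however, exchanged one saturated chain for another, while here an alkyl chain gives way to trifluoromethoxy, a group of a different kind with one hydrogen-bond acceptor. With no measured guidance for such an exchange, the expectation is a step of no more than the scatter in this assay, in either direction, with a widened range. Compound 3 is therefore estimated to give 24 uM, between 8 uM and 70 uM. The expected step is a 1.2-fold lower number from compound 2 to compound 3 (0.09 log units; within the scatter).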

Compound 3, concentration for half-maximal effect: 36.5 uM
Beside the measured number, compound 3's estimate is 1.5-fold (0.18 log units) below it, and the stated range covers the measured number.
By their numbers in this assay, from the lowest: compounds 1, 2 and 3 (each within the scatter of the next).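

In this assay, putting trifluoromethoxy in place of isobutyl on the aromatic carbon gives a 1.2-fold higher number from compound 2 to compound 3 (0.10 log units; within the scatter), and putting it in place of ethyl at that same carbon gives a 1.7-fold higher number from compound 1 to compound 3 (0.22 log units; within the scatter). The earlier pair differed only by one saturated chain against another, whereas compound 3 brings a group of a different kind to this place on the six-membered aromatic ring, with oxygen and fluorine in place of a purely carbon chain and with one hydrogen-bond acceptor, and still no step among these three compounds leaves the scatter. Across these three compounds, then, the read-out does not separate an alkyl chain from trifluoromethoxy at this carbon, and no measurement shown accounts for that result.

As far as these compounds go, whether an amine, a carboxylic acid or a much longer chain at this carbon would produce a step beyond the scatter remains open. Also open, from the compounds shown here alone, is whether any change elsewhere on the shared core would move the number more than these exchanges on the aromatic ring have done.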